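From ethyl to chloro: one small swap in compound 2

The compounds below may be only part of what the source reports. "The series", "measured", "known", "first", "only" and "open" are said of these compounds alone.

Three related compounds have been measured so far in a functional assay on A-375 cells (Homo sapiens) for inhibition, read by CCK-8 assay, with a stated time of 72 h, tested at 8 uM (on this read-out higher numbers stand for more inhibition of growth at the one concentration tested and lower numbers for less inhibition of growth), and all of them show clear inhibition of growth. Compound 2 (`CCc1ccc(SCc2ccc(C(=O)Nc3ccccc3N)cc2)cc1`) reaches 71.1% and compound 3 (`COC(=O)c1ccccc1SCc1ccc(C(=O)Nc2ccccc2N)cc1`) gives 70.1% in the same test, two numbers that lie within the usual scatter of each other. Compound 1 (`CCc1ccc(SCc2ccc(/C=C/C(=O)Nc3ccccc3N)cc2)cc1`) gives 58.4% and falls short of compound 2 by more than the scatter, so compound 2 stands in the upper pair of this small set.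

The next molecule, compound 4 (`Nc1ccccc1NC(=O)c1ccc(CSc2ccc(Cl)cc2)cc1`), keeps everything in compound 2 except one group. It carries chloro in place of ethyl on an aromatic carbon and so turns 4-ethylphenyl into 4-chlorophenyl.

Within the data shown here, no measured pair shows this exact swap, so the evidence is indirect. Compound 3 carries a different group on that same ring, yet its 70.1% stays within the scatter of compound 2 at 71.1% in this comparison. In this assay the step of a number 1.1 percentage points lower from compound 2 to compound 4 (within the scatter) is therefore expected to stay within the scatter, with no direction favoured. Compound 4 is estimated to give 70% with an expected range from 58% to 81% when it is tested.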

Compound 4, percent growth inhibition at one concentration: 48.6%
Compound 4: the middle estimate sits 21.4 percentage points above what was measured; measured number outside the range, below it.
By their numbers in this assay, from the lowest: compounds 4 and 1 (each within the scatter of the next); then compounds 3 and 2 (each within the scatter of the next).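

In this assay the swap of ethyl for chloro gives a number 22.5 percentage points lower from compound 2 to compound 4 (beyond the scatter) and so shows that this place on the ring, para to a large group, is sensitive to what sits there. The change is small on paper: 2 heavy carbon atoms leave, 1 chlorine enters, and neither group has a ring, a charge, or any hydrogen-bond donors or acceptors, yet that is enough to carry the number beyond the usual scatter. Nothing available explains why this swap lowers the number.

Going by these compounds, it remains open whether the drop reflects something that chloro brings or something that ethyl takes away, and a methyl group, a propyl chain, a methoxy group or an amine at the same place could help to separate these two readings. On these data alone, it is also open whether the same swap from ethyl to chloro would lower the number on compound 1 , whose core differs from that of compound 2 , or whether this step holds only for the core shared by compound 2 and compound 4 .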